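The compounds below may be only part of what the source reports. "The series", "measured", "known", "first", "only" and "open" are said of these compounds alone.

Compound 1, `COc1cc(OC)cc(C(=O)Nc2ccc(Nc3nc(C)cc(N(C)C)n3)cc2)c1`, gives 20000 nM in a physicochemical assay for solubility, read by nephelometry, measured as kinetic solubility; a lower number here means a less soluble compound, a higher number a more soluble compound.
Compound 2, `COc1cccc(Nc2nc(C)cc(N(C)C)n2)c1`, gives > 250000 nM in this assay.

Compound 2 stands at a limit of this assay, not at a measured number (the limit of > 250000 nM in this assay, at which 1 of the 2 values shown sits). Of the two values shown, compound 1 sits at a number and compound 2 at the limit, so compound 2 stands at the soluble end of what has been measured.

Compound 3, `COc1cc(Nc2nc(C)cc(N(C)C)n2)ccc1F`, differs from compound 2 in one place: fluoro in place of hydrogen on an aromatic carbon. For the measured compounds named here, no measured pair in this set shows a step of this kind, so the size of the step in this assay has to be judged without a precedent. The step from compound 2 to compound 3 is expected to be small, within the usual scatter or at most a modest loss of solubility, an at least 1.2-fold lower number from compound 2 to compound 3 (0.09 log units; that floor lies within the scatter). Compound 3 is therefore expected to read near the limit, at about 200000 nM, between 80000 nM and 300000 nM.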

Compound 3, solubility: > 250000 nM
Compound 3 gave a limit, no number (the forecaster's own chance of this, stated with the estimate: 55%); middle value at least 1.2-fold (0.09 log units) away from the limit.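

For the compounds shown here, compound 2 and compound 3 both stand at a limit of this assay, not at a number, so no step between them can be read: the limit of > 250000 nM in this assay, at which 2 of the 3 values shown sit.

The compounds shown leave open what size of step, if any, fluoro in place of hydrogen on an aromatic carbon brings in this assay.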